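Anilinothiazole chalcones in the prostate tumour cell assay

The compounds below may be only part of what the source reports. "The series", "measured", "known", "first", "only" and "open" are said of these compounds alone.

Measured so far in a functional assay on PC-3 cells (Homo sapiens) for cytotoxicity, read by MTT assay; on this read-out higher numbers stand for weaker inhibition and lower numbers for stronger inhibition:
compound 1 `COc1cccc(/C=C/C(=O)c2sc(Nc3cccc(C)c3)nc2C)c1`, limit of > 25000 nM.
compound 2 `Cc1nc(Nc2ccc(Cl)cc2)sc1C(=O)/C=C/c1ccc(Cl)cc1`, limit of > 25000 nM.
compound 3 `COc1cc(/C=C/C(=O)c2sc(Nc3cccc(Cl)c3)nc2C)cc(OC)c1OC`, limit of > 25000 nM.

All three numbers are limits of this assay, not measured values. Compound 3 is therefore not placed among the others: its result in this assay is a limit, and the two further results shown are limits as well. Among the compounds with values here, the one piece of evidence on the set is the limit of > 25000 nM in this assay, at which 3 of the 3 values shown sit, which gives no rank between compound 1, compound 2 and compound 3.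

The next compound, compound 4 `COc1cc(/C=C/C(=O)c2sc(Nc3ccccc3C)nc2C)cc(OC)c1OC`, keeps the shared core of compound 3 and carries 2-methylphenyl in place of 3-chlorophenyl on a nitrogen on an aromatic ring, in words: 2-methylphenyl in place of 3-chlorophenyl on a nitrogen on an aromatic ring. Within the data shown here, no step between measured compounds exists here, so the size of this change is untested.

Given that compound 3 sits at the limit (the limit of > 25000 nM in this assay, at which 3 of the 3 values shown sit), the expected step from compound 3 to compound 4 in this assay is none beyond the scatter, as a step that the limit leaves unreadable from compound 3 to compound 4, and the estimate for compound 4 in this assay is 40000 nM, in the range 12000 nM to 150000 nM, most likely reported again as a limit.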

Compound 4, half-maximal inhibitory concentration: > 25000 nM
Compound 4: a limit, no number; the forecaster's own chance of this, stated with the estimate: 85%; the middle value does not contradict the limit.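

No step can be read from compound 3 to compound 4 in this assay, since both results are limits and not numbers. The whole set stays at one value: the limit of > 25000 nM in this assay, at which 4 of the 4 values shown sit.

The compounds shown leave open how these four rank against each other and whether any change on the shared core would give a measurable value in this assay.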